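Side-chain change from compound 2 to compound 3

This account rests on a few compounds, and the source may have more. Where it says the series, first, only, none or still open, it means among the compounds named here.

- compound 1 `CCOc1cc(C(C)(C)C)ccc1C1=N[C@@](C)(c2ccc(Cl)cc2)[C@@](C)(c2ccc(Cl)cc2)N1C(=O)N1CCN(CCC(F)(F)F)CC1` gives 5000 nM
- compound 2 `CCOc1cc(C(C)(C)C)ccc1C1=N[C@@](C)(c2ccc(Cl)cc2)[C@@](C)(c2ccc(Cl)cc2)N1C(=O)N1CCN(CCNC(C)=O)CC1` gives 11000 nM

In a functional assay on SW480 cells (Homo sapiens) for cytotoxicity, read by MTT assay, with a stated time of 5 days (a higher number here means a weaker inhibitor, a lower number a stronger inhibitor), compound 2 (11000 nM) holds the highest of the two numbers. Compound 3 `CCOc1cc(C(C)(C)C)ccc1C1=N[C@@](C)(c2ccc(Cl)cc2)[C@@](C)(c2ccc(Cl)cc2)N1C(=O)N1CCN(CC(=O)N2CCCC2)CC1` differs from it by (pyrrolidin-1-yl)carbonyl in place of acetamidomethyl on a saturated chain carbon bound to an amine nitrogen in a ring on the same side chain, read further out as 2-acetamidoethyl to ((pyrrolidin-1-yl)carbonyl)methyl. Among the compounds with values here, the only measured step on this chain (a 2.2-fold higher number from compound 1 to compound 2 (0.34 log units; beyond the scatter)) is modest, though beyond the scatter. A similarly small change is therefore expected in this assay with no clear direction, and the expected 1.2-fold lower number from compound 2 to compound 3 (0.09 log units; within the scatter) stays within the scatter. Compound 3 is estimated at 9000 nM (expected range 4500 nM to 18000 nM).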

Compound 3, half-maximal inhibitory concentration: 14400 nM
Beside the measured number, compound 3's estimate is 1.6-fold (0.20 log units) below it; the measured number falls inside the stated range.
By their numbers in this assay, from the lowest: compound 1; then compounds 2 and 3 (each within the scatter of the next).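

In this assay, the hydrogen-bond donor of acetamidomethyl leaves and a five-membered non-aromatic ring enters with no step outside the scatter (a 1.3-fold higher number from compound 2 to compound 3 (0.12 log units; within the scatter)), so this place on the chain tolerates that exchange. Against 2,2,2-trifluoroethyl, the (pyrrolidin-1-yl)carbonyl group gives a modest step (a 2.9-fold higher number from compound 1 to compound 3 (0.46 log units; beyond the scatter)), leaving compound 1 below both amide-bearing compounds 2 and 3. Nothing measured here accounts for these steps. Going by these compounds, whether a basic amine, a carboxylic acid or a longer chain at this place would give a clearly lower number remains open.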